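Replacing a Nitrophenyl Group with a Pentyl Chain

This account rests on a few compounds, and the source may have more. Where it says the series, first, only, none or still open, it means among the compounds named here.

Measured so far in a functional assay on HT-29 cells (Homo sapiens) for inhibition, read by MTT assay, with a stated time of 2 days; a higher number here means a weaker inhibitor of growth, a lower number a stronger inhibitor of growth:
Compound 1 `O=C(Nn1c(-c2cccc([N+](=O)[O-])c2)nc2c(-c3ccc(Cl)cc3)n[nH]c2c1=O)c1ccccc1` gives 18500 nM.
Compound 2 `O=C(Nn1c(CCc2ccccc2)nc2c(-c3ccc(Cl)cc3)n[nH]c2c1=O)c1ccccc1` gives 23400 nM.
Compound 3 `CCCc1nc2c(-c3ccc(Cl)cc3)n[nH]c2c(=O)n1NC(=O)c1ccccc1` gives 9260 nM.

Compound 1 stands second highest of these three numbers; a 1.3-fold higher number from compound 1 to compound 2 (0.10 log units; within the scatter) and a 2.0-fold lower number from compound 1 to compound 3 (0.30 log units; within the scatter) describe its nearest and furthest neighbours. Compound 4 `CCCCCc1nc2c(-c3ccc(Cl)cc3)n[nH]c2c(=O)n1NC(=O)c1ccccc1` is not yet measured. It differs from compound 1 in one place: pentyl in place of 3-nitrophenyl on an aromatic carbon. Going by the values given here, two measured steps bear on this change, since both replace the same 3-nitrophenyl on the shared core, and both stay within the scatter. Between those two replacements, a 2.5-fold lower number from compound 2 to compound 3 (0.40 log units; beyond the scatter) counts as modest. A pentyl chain sits between propyl and phenethyl in size, so the expected step of a 1.4-fold lower number from compound 1 to compound 4 (0.15 log units; within the scatter) is estimated to stay within the scatter. Compound 4 is therefore expected to give 13000 nM, within 5500 nM to 30000 nM.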

Compound 4, concentration for 50% growth inhibition: 2260 nM
Compound 4: the middle estimate sits 5.8-fold (0.76 log units) above what was measured; measured number outside the range, below it.
By their numbers in this assay, from the lowest: compound 4; then compounds 3, 1 and 2 (each within the scatter of the next, the first and the last beyond it).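

In this assay, going by these compounds alone, this aromatic carbon proves more sensitive than the earlier compounds suggested: pentyl in place of 3-nitrophenyl gives an 8.2-fold lower number from compound 1 to compound 4 (0.91 log units; beyond the scatter), a clear drop in the number. Chain length matters too, with ethyl in place of a hydrogen on the propyl chain giving a 4.1-fold lower number from compound 3 to compound 4 (0.61 log units; beyond the scatter), and propyl in place of the phenyl of the phenethyl group giving a 10-fold lower number from compound 2 to compound 4 (1.02 log units; beyond the scatter). Nothing available accounts for these differences.

Going by these compounds, whether a longer chain such as heptyl would lower the number further remains open. So does the effect of an amine at the end of the pentyl chain.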